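The source may hold more compounds than are shown below. What is called first, only, known or untested is meant among the compounds shown, and "the series" means these compounds.

Measured compounds:
Compound 1 `Cc1ccccc1CNC(=O)c1nc(-c2ccc(F)cc2)n(CC[C@@H](O)C[C@@H](O)CC(=O)O)c1C1CC1` gives 4.9 nM in an assay on microsomes from liver for inhibition of 3-hydroxy-3-methylglutaryl-coenzyme A reductase (Rattus norvegicus), read by scintillation counting, with stated times of 0.5 h and 0.75 h; a higher number here means a weaker inhibitor, a lower number a stronger inhibitor.
Compound 2 `O=C(O)C[C@H](O)C[C@H](O)CCn1c(-c2ccc(F)cc2)nc(C(=O)NCc2ccc(F)cc2)c1C1CC1` gives 3.4 nM in this assay.
Compound 3 `CCc1c(C(=O)NCc2ccccc2)nc(-c2ccc(F)cc2)n1CC[C@@H](O)C[C@@H](O)CC(=O)O` gives 123 nM in this assay.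

Compound 3 has the highest number of the three, with compound 1 nearest and compound 2 furthest; both gaps lie beyond the scatter. Compound 4 `O=C(O)C[C@H](O)C[C@H](O)CCn1c(-c2ccc(F)cc2)nc(C(=O)NCc2ccccc2)c1C1CC1` has not yet been measured. It arises from compound 3 by a single change: cyclopropyl in place of ethyl on an aromatic carbon. Compounds 1 and 2 both carry that cyclopropyl group on the same ring carbon, and they differ from compound 4 only in the substituent on the benzylcarbamoyl group. For the measured compounds named here, the one measured step that bears on this, a 1.4-fold lower number from compound 1 to compound 2 (0.16 log units; within the scatter), shows that a change at that benzyl position moves the number little. So the value of compound 4 is expected to lie close to those of compound 1 and compound 2, which means a large downward step from compound 3. The estimate for compound 4 in this assay is 6 nM, with a range from 2 nM to 25 nM; the estimated step of a 21-fold lower number from compound 3 to compound 4 (1.31 log units; beyond the scatter) is well beyond the scatter, though no direct measurement of ethyl against cyclopropyl exists here to confirm it.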

Compound 4, half-maximal inhibitory concentration: 1.4 nM
The estimate for compound 4 lay 4.3-fold (0.63 log units) above the measured number, outside the stated range (below it).
By their numbers in this assay, from the lowest: compound 4; then compounds 2 and 1 (each within the scatter of the next); then compound 3.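

In this assay, for the compounds shown here, the replacement of ethyl by cyclopropyl, on the aromatic carbon next to the ring nitrogen, gives an 88-fold lower number from compound 3 to compound 4 (1.94 log units; beyond the scatter) and provides the first direct reading at this position, with the unsubstituted benzylcarbamoyl group held the same on both sides. Compound 4 also gives the benzyl ring a reference point: the earlier pair suggested that a substituent there moves the number little, yet removing fluoro gives a 2.4-fold lower number from compound 2 to compound 4 (0.39 log units; beyond the scatter) and removing methyl gives a 3.5-fold lower number from compound 1 to compound 4 (0.54 log units; beyond the scatter), so both substituted compounds sit modestly on the weaker side of the plain benzyl group, although these steps are far smaller than the one at the ethyl position. No measurement offered here accounts for the size of any of these steps.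

On these data alone, only ethyl and cyclopropyl can be compared at this ring carbon, so it remains open where a methyl, an isopropyl or a cyclobutyl group would fall. The ethyl group is also shown only with the plain benzyl group, and on the benzyl ring only methyl and fluoro stand against hydrogen, which leaves open how a chloro or methoxy group would behave there.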